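Bromofluorophenyl analogue of a dihydropyridine Notch inhibitor series

The compounds below may be only part of what the source reports. "The series", "measured", "known", "first", "only" and "open" are said of these compounds alone.

Measured so far:
compound 1 `CC1=C(C(=O)OC2CCCCC2)C(c2ccc3c(c2)OCCO3)C2=C(CC(C)(C)CC2=O)N1` — 12300 nM
compound 2 `CC1=C(C(=O)OCCC2CCN(C(=O)OC(C)(C)C)CC2)C(c2cccc(Br)c2)C2=C(CC(C)(C)CC2=O)N1` — 2950 nM
compound 3 `CC1=C(C(=O)OCC2CCN(C(=O)OC(C)(C)C)CC2)C(c2ccc3c(c2)OCCO3)C2=C(CC(C)(C)CC2=O)N1` — 1520 nM

Three compounds sharing one core have been run in an assay on HEK293 cells for inhibition of neurogenic locus notch homolog protein 1 (Homo sapiens), read by a luciferase reporter and resazurin assay, with a stated time of 16 h; a higher number here means a weaker inhibitor, a lower number a stronger inhibitor. Compound 1 carries a cyclohexyl ester and gives 12300 nM. Compound 2, with a piperidinylethyl ester and a bromophenyl group on the saturated ring carbon, gives 2950 nM. Compound 3, with a piperidinylmethyl ester and a benzodioxinyl group, gives 1520 nM, the lowest number of the three: its gap to compound 1 lies beyond the scatter, while its gap to compound 2 lies within it, so compound 2 and compound 3 are not separated by this assay.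

Compound 4 `CC1=C(C(=O)OCC2CCN(C(=O)OC(C)(C)C)CC2)C(c2ccc(Br)cc2F)C2=C(CC(C)(C)CC2=O)N1` keeps the ester of compound 3 and changes only the aryl group: 4-bromo-2-fluorophenyl in place of 2,3-dihydro-1,4-benzodioxin-6-yl on a saturated ring carbon. For the measured compounds named here, no pair of measured compounds differs in exactly this way, so the step has no direct precedent. Compound 2 shows that a halogenated phenyl on that carbon is compatible with a number in the same range as compound 3, though compound 2 also differs in its ester chain. The account therefore expects for the step from compound 3 to compound 4 a change of a 1.3-fold higher number from compound 3 to compound 4 (0.12 log units; within the scatter), that is, nothing clearly beyond the scatter. Compound 4 is estimated at 2000 nM, within a range from 700 nM to 6000 nM.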

Compound 4, half-maximal inhibitory concentration: > 10000 nM
Compound 4 ended at the assay's limit; the forecaster's own chance of this, stated with the estimate: 3%; middle value at least 5.0-fold (0.69 log units) from the limit.
By their numbers in this assay, from the lowest: compounds 3 and 2 (each within the scatter of the next); then compound 1.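

In this assay, compound 4 stands at a limit of the assay, > 10000 nM, and not at a number. With the ester of compound 3 held fixed, 4-bromo-2-fluorophenyl in place of 2,3-dihydro-1,4-benzodioxin-6-yl on this saturated ring carbon gives an at least 6.5-fold higher number from compound 3 to compound 4 (0.81 log units; beyond the scatter), which shows that the choice of aryl group at this position can by itself move the result beyond the scatter. The earlier compounds held no pair differing at this position alone, so this is the first reading of the position on its own, and the size of the step stands only as a bound: the limit of > 10000 nM in this assay, at which 1 of the 4 values shown sits.

The compounds shown leave open which part of the change carries the step: the bromine, the fluorine, or the loss of the 2,3-dihydro-1,4-benzodioxin-6-yl group, as none of them has a phenyl with bromine alone or fluorine alone on this ester. Also open, as far as these compounds go, is whether a methoxy group or an amine on the phenyl ring, with the same piperidinylmethyl ester, would keep a measurable number in this assay.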